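The compounds below may be only part of what the source reports. "The series", "measured", "known", "first", "only" and "open" are said of these compounds alone.

In an ADME assay on liver for metabolic stability, with Liver microsome (Homo sapiens) as the target, read by LC-MS, using microsomes (a higher number here means faster removal of the compound, a lower number slower removal), compound 3 `COC(C)(C)[C@@H](O)C(=O)N1C[C@H]2C[C@H]2[C@H]1C(=O)NCc1cc(Cl)ccc1-n1cnnn1` stands at 23 mL.min-1.g-1 and compound 1 `O=C(NCc1cc(Cl)ccc1-n1cnnn1)[C@@H]1CC=NN1C(=O)[C@H](O)c1ccccc1F`, which has a core of its own, at 16 mL.min-1.g-1 within the scatter of compound 3. Compound 2 `O=C(NCc1cc(Cl)ccc1-n1cnnn1)[C@@H]1CC=NN1C(=O)[C@H](O)Cc1ccccc1` reads < 12 mL.min-1.g-1 as a limit of the assay and not a number.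

Compound 4 `O=C(NCc1cc(Cl)ccc1-n1cnnn1)[C@@H]1[C@@H]2C[C@@H]2CN1C(=O)[C@H](O)c1ccccc1F` keeps the core of compound 3 and carries 2-fluorophenyl in place of 1-methoxy-1-methylethyl on a saturated chain carbon bound to a carbonyl carbon and an oxygen on a saturated carbon, and 2-fluorophenyl in place of 1-methoxy-1-methylethyl on a saturated chain carbon bound to a carbonyl carbon and an oxygen on a saturated carbon gives the count of that change.

Among the measured compounds shown here, no measured step replaces 1-methoxy-1-methylethyl. For the measured compounds named here, the one measured step at that carbon is an at least 1.3-fold lower number from compound 1 to compound 2 (0.12 log units; that floor lies within the scatter) with benzyl in place of 2-fluorophenyl, and it rests on the limit of < 12 mL.min-1.g-1 in this assay, at which 1 of the 3 values shown sits, so it gives a floor only. Compound 1, which carries the entering 2-fluorophenyl, sits at 16 mL.min-1.g-1 within the scatter of compound 3, so no step beyond the scatter is expected in this assay for this change. The estimated change is a 1.1-fold lower number from compound 3 to compound 4 (0.04 log units; within the scatter) and is expected to stay within the scatter. For compound 4 the estimate is 21 mL.min-1.g-1 with 11 mL.min-1.g-1 to 40 mL.min-1.g-1 as its expected range.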

Compound 4, intrinsic clearance in microsomes: < 12 mL.min-1.g-1
Compound 4: only a limit was reported; the forecaster's own chance of this, stated with the estimate: 10%; middle value at least 1.7-fold (0.24 log units) from the limit.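

In this assay, among the compounds shown here, the carbon bound to a carbonyl carbon and an oxygen now has a measured step that replaces 1-methoxy-1-methylethyl, which none of the earlier compounds gave: 2-fluorophenyl in its place gives an at least 1.9-fold lower number from compound 3 to compound 4 (0.28 log units; that floor lies within the scatter). This step is a floor and not a size, so on the core of compound 3 the change is not shown to go beyond the scatter, although a larger gap is not excluded. The value of compound 4 is a limit of the assay, and with it the only two steps at this carbon both rest on such a limit: the limit of < 12 mL.min-1.g-1 in this assay, at which 2 of the 4 values shown sit.

From the compounds shown here alone, the real sizes of both steps stay open, as does the question of whether 2-fluorophenyl and 1-methoxy-1-methylethyl would compare in the same way on the core of compound 1. Also open, going by these compounds, is what an amine, a carboxylic acid or a longer chain at this carbon would give on either core in this assay.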